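A Cyanomethyl Variant of the Weakest Sulfonamide

A few compounds are considered here, and "the series" means these few. Any claim that something is new, unique, unknown or untested is made for them only; others in the source may bear on it.

In an assay on cells for antagonist activity at transient receptor potential cation channel subfamily V member 1 (Homo sapiens), read by FLIPR and calcium flux, with a stated time of 15 min (a higher number here means a weaker inhibitor, a lower number a stronger inhibitor), three compounds on one shared core have been measured. Compound 1 `CC1CCN(c2nc(C(F)(F)F)ccc2CNC(=O)C(C)c2ccc(NS(=O)(=O)C(C)C)c(F)c2)CC1` gives 8.7 nM. Compound 2 `CC1CCN(c2nc(C(F)(F)F)ccc2CNC(=O)C(C)c2ccc(NS(N)(=O)=O)c(F)c2)CC1` gives 2.7 nM. Compound 3 `CC1CCN(c2nc(C(F)(F)F)ccc2CNC(=O)C(C)c2ccc(N(C)S(C)(=O)=O)c(F)c2)CC1` gives 55.5 nM, the highest number of the three. The measured steps run a 3.2-fold lower number from compound 1 to compound 2 (0.51 log units; beyond the scatter), a 6.4-fold higher number from compound 1 to compound 3 (0.80 log units; beyond the scatter) and a 21-fold higher number from compound 2 to compound 3 (1.31 log units; beyond the scatter), all beyond the scatter. Compound 4 `CC1CCN(c2nc(C(F)(F)F)ccc2CNC(=O)C(C)c2ccc(N(CC#N)S(C)(=O)=O)c(F)c2)CC1` differs from compound 3 by cyano in place of hydrogen on a saturated chain carbon bound to a sulfonamide nitrogen. For the measured compounds named here, none of the measured steps touches a saturated chain carbon bound to the sulfonamide nitrogen: one changes the group on the sulfonyl sulfur, the other two exchange the whole substituent on the aromatic carbon. They show that this region responds to change, but give no direction for this particular alteration. For compound 4 the account therefore expects a step of a 1.1-fold lower number from compound 3 to compound 4 (0.05 log units; within the scatter), which is within the usual scatter and carries no firm direction. Compound 4 is estimated at 50 nM, in a range from 18 nM to 160 nM.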

Compound 4, inhibition constant: "not active" (no number reported)
Compound 4 has no reported number here; no gap can be computed for the estimate.
By their numbers in this assay, from the lowest: compound 2; then compound 1; then compound 3.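

For the compounds shown here, compound 4 is reported only as "not active", without a number, so no step from compound 3 to compound 4 can be read in this assay. Nothing shown here offers an explanation for this result. The compounds shown leave open how far compound 4 actually lies from compound 3.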